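This account rests on a few compounds, and the source may have more. Where it says the series, first, only, none or still open, it means among the compounds named here.

Measured in an ADME assay on microsomes from liver (Homo sapiens) for metabolic stability; a lower number here means that the compound disappears faster, a higher number that the compound lasts longer:
compound 1 `CC(C)C(CC1C(=O)NC(=O)N1C)c1ccc(-c2ccc3cccc(F)c3c2)[nH]c1=O` gives 0.153 h
compound 2 `CC(C)C(c1ccc(-c2ccc3cccc(F)c3c2)[nH]c1=O)C1SC(=O)NC1=O` gives 1.87 h
compound 3 `CC(C)C(CC1NC(=O)NC1=O)c1ccc(-c2ccc3cccc(F)c3c2)[nH]c1=O` gives 1.59 h

Compound 3 lies within the scatter of compound 2, with a 1.2-fold lower number from compound 2 to compound 3 (0.07 log units; within the scatter), and well clear of compound 1, with a 10-fold higher number from compound 1 to compound 3 (1.02 log units; beyond the scatter).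

Compound 4 `CC(C)C(/C=C1/C(=O)NC(=O)N1C)c1ccc(-c2ccc3cccc(F)c3c2)[nH]c1=O` differs from compound 3 as follows: a group of 9 heavy atoms (5 carbon, 2 nitrogen, 2 oxygen; one five-membered non-aromatic ring with 2 hetero atoms) in place of a group of 8 heavy atoms (4 carbon, 2 nitrogen, 2 oxygen; one five-membered non-aromatic ring with 2 hetero atoms), on a saturated chain carbon bound to an aromatic carbon and a saturated chain carbon. Compound 4 shares with compound 1 the methyl on an amide-type nitrogen in a ring, so a 10-fold higher number from compound 1 to compound 3 (1.02 log units; beyond the scatter) is the step that bears most directly, read in reverse. Going by the values given here, no measured compound carries the added double bond outside aromatic rings, so part of that large step may not carry over. A clear fall is therefore expected, smaller than the full reverse step, and the estimated step is a 4.0-fold lower number from compound 3 to compound 4 (0.60 log units; beyond the scatter). For compound 4 the expected half-life is 0.4 h, with an estimated range from 0.12 h to 1.3 h.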

Compound 4, half-life in the Homo sapiens assay: > 3 h
Compound 4: only a limit was reported; the forecaster's own chance of this, stated with the estimate: 3%; middle value at least 7.5-fold (0.87 log units) from the limit.
By their numbers in the Homo sapiens assay, from the lowest: compound 1; then compounds 3 and 2 (each within the scatter of the next). At a limit, above all of these: compound 4.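

In the Homo sapiens assay compound 4 gives > 3 h, which is a limit and not a number: the limit of > 3 h in the Homo sapiens assay, at which 1 of the 4 values shown sits. The methyl on an amide-type nitrogen in a ring stands on both sides of a large step, an at least 19-fold higher number from compound 1 to compound 4 (1.29 log units; beyond the scatter), and in this place that methyl alone does not fix a low number. The floors of the other two steps, an at least 1.8-fold higher number from compound 3 to compound 4 (0.27 log units; that floor lies within the scatter) and an at least 1.6-fold higher number from compound 2 to compound 4 (0.20 log units; that floor lies within the scatter), lie within the scatter, and the full size of these gaps cannot be read. In a physicochemical assay for solubility, measured as kinetic solubility, at pH 2 (a higher number here means a more soluble compound, a lower number a less soluble compound), compound 3 gives 13000 nM and compound 4 gives 8300 nM, two values within the scatter of each other.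

Still open, from the compounds shown here alone, is whether the added double bond would hold this number without the methyl. Also open, going by these compounds, is how an amine or a carboxylic acid would read on this saturated chain carbon.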